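Carbonyl-bound aromatic group: from compound 1 to compound 4

This account rests on a few compounds, and the source may have more. Where it says the series, first, only, none or still open, it means among the compounds named here.

Measured in a functional assay on the whole organism (blood) with Rattus norvegicus as the target, with stated times of 24 h and 1 h, at a dose of 15 mg/kg by the intraperitoneal route; a lower number here means a weaker effect, a higher number a stronger effect of the compound at the dose given:
compound 1 `Cn1cc(C(=O)NCCC2CCN(S(=O)(=O)NC(=O)NC3CCCCC3)CC2)c(=O)n(C)c1=O` — 15%
compound 2 `O=C(NC[C@@H]1C[C@@H]2C=C[C@@H]1C2)NS(=O)(=O)N1CCC(CCNC(=O)c2cc(Cl)ccn2)CC1` — 46%
compound 3 `Cn1cccc(C(=O)NCCC2CCN(S(=O)(=O)NC(=O)NC[C@@H]3C[C@@H]4C=C[C@@H]3C4)CC2)c1=O` — 40%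

Compound 1 gives the lowest of the three numbers, and its distance to compound 3 and to compound 2 is beyond the scatter in both cases. Compound 4 `O=C(NC1CCCCC1)NS(=O)(=O)N1CCC(CCNC(=O)c2nsc3ccccc23)CC1` is the next candidate, differing from compound 1 only at the carbonyl carbon: a group of 9 heavy atoms (7 carbon, 1 nitrogen, 1 sulfur; one five-membered aromatic ring with 2 hetero atoms, one six-membered aromatic ring of carbon only) in place of a group of 10 heavy atoms (6 carbon, 2 nitrogen, 2 oxygen; one six-membered aromatic ring with 2 hetero atoms), on a carbonyl carbon. Among the compounds with values here, one measured step touches the same site, a number 6 percentage points lower from compound 2 to compound 3 (within the scatter), and it stayed within the scatter, so one exchange of the aromatic group on that carbonyl carbon changed little. That is thin ground, and the entering group here is of another kind, so the expectation is loose. Compound 4 is expected to shift by a number 10 percentage points higher from compound 1 to compound 4 (within the scatter), a small rise that may itself fall within the scatter. The estimate for compound 4 is 25%, spanning 5% to 50%.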

Compound 4, a percentage reported as activity, at one dose (the size of the read-out at that dose, not a potency): 17%
The estimate for compound 4 lay 8 percentage points above the measured number, within the range that was stated.
By their numbers in this assay, from the lowest: compounds 1 and 4 (each within the scatter of the next); then compounds 3 and 2 (each within the scatter of the next).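

In this assay the exchange on the carbonyl carbon gives a number 2 percentage points higher from compound 1 to compound 4 (within the scatter) even though two aromatic rings replace one and the hydrogen-bond acceptors go from 4 to 2. On the core of compound 1, a group of quite another kind therefore leaves the read-out unchanged within the scatter, so the earlier exchange of one single aromatic ring for another is no longer the only such case. Nothing at hand accounts for this result.

Going by these compounds, whether any group on this carbonyl carbon moves the read-out beyond the scatter on this core stays open, for example a phenyl ring carrying a carboxylic acid. Also open, on these data alone, is whether the group of compound 4 would behave the same way on the core of compound 3.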